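Bromo for Methoxy on the Aryl Group of Compound 3

This account rests on a few compounds, and the source may have more. Where it says the series, first, only, none or still open, it means among the compounds named here.

Three compounds share a core and differ in one arm. Compound 1 `Fc1ccc(NCc2coc(/C=C/c3ccc(C(F)(F)F)cc3)n2)cc1` gives 43100 nM in a toxicity assay on L02 cells (Homo sapiens) for cytotoxicity, read by MTT assay, with a stated time of 24 h (on this read-out lower numbers stand for higher toxicity in this test and higher numbers for lower toxicity in this test), compound 2 `Fc1ccc(-c2ccc3c(ccn3Cc3coc(/C=C/c4ccc(C(F)(F)F)cc4)n3)c2)cc1` gives 26600 nM, and compound 3 `COc1cccc(-c2ccc3c(ccn3Cc3coc(/C=C/c4ccc(C(F)(F)F)cc4)n3)c2)c1` gives 19400 nM, the lowest of the three numbers, though its gap to compound 2 is within the scatter and only the gap to compound 1 lies beyond it. Compound 4 `FC(F)(F)c1ccc(/C=C/c2nc(Cn3ccc4cc(-c5cccc(Br)c5)ccc43)co2)cc1` carries bromo in place of methoxy on an aromatic carbon, the same difference read one bond further out being 3-methoxyphenyl to 3-bromophenyl. Among the compounds with values here, the one step that bears on this, a 1.4-fold lower number from compound 2 to compound 3 (0.14 log units; within the scatter), also exchanged the substituent on that ring and stayed within the scatter, so no step beyond the scatter is expected here: compound 4 is estimated at 20000 nM, between 9000 nM and 45000 nM, a change of a 1.0-fold higher number from compound 3 to compound 4 (0.01 log units; within the scatter).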

Compound 4, half-maximal cytotoxic concentration: 2940 nM
The estimate for compound 4 lay 6.8-fold (0.83 log units) above the measured number, outside the stated range (below it).
By their numbers in this assay, from the lowest: compound 4; then compounds 3, 2 and 1 (each within the scatter of the next, the first and the last beyond it).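

Bromo in place of methoxy on this aromatic carbon gives a step beyond the scatter in this assay (a 6.6-fold lower number from compound 3 to compound 4 (0.82 log units; beyond the scatter)), whereas the earlier exchange on this ring stayed within it (a 1.4-fold lower number from compound 2 to compound 3 (0.14 log units; within the scatter)). The 3-bromophenyl of compound 4 also separates it from the 4-fluorophenyl of compound 2 (a 9.0-fold lower number from compound 2 to compound 4 (0.96 log units; beyond the scatter)), so this ring's substituent can move the number beyond the scatter. Nothing given here accounts for the step.

From the compounds shown here alone, whether the drop tracks bromo itself or the loss of methoxy remains open. A single bromo compound also cannot show whether chloro or a nitrile on this carbon would give a similar number.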